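Urea to benzamide on the anilide of compound 2

The source may report more compounds than this note shows. Statements on the series, on what has been measured and on what is new or still open speak of the compounds shown alone.

compound 1 `O=C(Nc1cccc(-n2cc(-c3ccncc3)c(-c3ccc(Cl)c(O)c3)n2)c1)Nc1cccc(C(F)(F)F)c1`: > 32500 nM
compound 2 `COc1cc(-c2nn(-c3cccc(NC(=O)Nc4cccc(C(F)(F)F)c4)c3)cc2-c2ccncc2)ccc1Cl`: 5420 nM

For the measured compounds named here, in a functional assay on HCT-15 cells (Homo sapiens) for inhibition, read by sulforhodamine B assay, with a stated time of 48 h (a lower number here means a stronger inhibitor of growth, a higher number a weaker inhibitor of growth), compound 2 gives 5420 nM, the only true number in the set. For compound 1 this assay reports only a limit, > 32500 nM. The step of an at least 5.9-fold lower number from compound 1 to compound 2 (0.77 log units; beyond the scatter) arises from a single change on the oxygen of the aromatic ring; its size is bounded by the limit of > 32500 nM in this assay, at which 1 of the 2 values shown sits, and is therefore known only as a floor. Compound 3 `COc1cc(-c2nn(-c3cccc(NC(=O)c4ccccc4)c3)cc2-c2ccncc2)ccc1Cl` differs from compound 2 at the carbonyl: phenyl in place of (3-(trifluoromethyl)phenyl)amino on a carbonyl carbon. Going by the values given here, no measured step touches this part of the molecule; the one step in hand concerns the methoxy group, which compounds 2 and 3 share. Expectation therefore rests on compound 2 alone and carries wide uncertainty. Compound 3 is estimated at 15000 nM (range 4000 nM to 60000 nM). The step of a 2.8-fold higher number from compound 2 to compound 3 (0.44 log units; beyond the scatter) is expected to run toward a weaker number, with a fair chance that only a limit is reported.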

Compound 3, concentration for total growth inhibition: > 100000 nM
Compound 3: a limit, no number; the forecaster's own chance of this, stated with the estimate: 35%; middle value at least 6.6-fold (0.82 log units) from the limit.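

At the carbonyl carbon, phenyl in place of (3-(trifluoromethyl)phenyl)amino gives an at least 18-fold higher number from compound 2 to compound 3 (1.26 log units; beyond the scatter) in this assay, so growth inhibition in this series depends on this position and not only on the group on the aromatic oxygen. Compound 3 reports only a limit, > 100000 nM, so the size of this step is known only as a floor: the limit of > 100000 nM in this assay, at which 1 of the 3 values shown sits.

The change removes the trifluoromethyl group and the amino nitrogen with its hydrogen in one step, and the compounds shown do not separate the two. Open, from the compounds shown here alone, is whether a plain phenylamino group or a 3-(trifluoromethyl)phenyl group on the carbonyl carbon would stay near compound 2 at 5420 nM, or fall with compound 3.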